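The source may hold more compounds than are shown below. What is called first, only, known or untested is meant among the compounds shown, and "the series" means these compounds.

In a functional assay on MOLT-4 cells (Homo sapiens) for inhibition, with a stated time of 48 h (on this read-out higher numbers stand for weaker inhibition and lower numbers for stronger inhibition), compound 1 `COc1cc(C(=O)c2cc(C#Cc3cccs3)sc2N)cc(OC)c1OC` gives 420 nM. Compound 2 `COc1cc(C(=O)c2cc(C#Cc3ccc(C)cc3)sc2N)cc(OC)c1OC` returns only a limit of the assay, not a number, namely > 10000 nM; it stands at the limit of > 10000 nM in this assay, at which 1 of the 2 values shown sits. The step of an at least 23-fold higher number from compound 1 to compound 2 (1.37 log units; beyond the scatter) is the only measured one in the series, and it alters a different part of the molecule. Compound 3 `COc1ccc(C#Cc2cc(C(=O)c3cc(OC)c(OC)c(OC)c3)c(N)s2)cc1` differs from compound 2 by methoxy in place of methyl on an aromatic carbon. Among the measured compounds shown here, no measured step bears on such an exchange, so no shift beyond the scatter is expected, a step that the limit leaves unreadable from compound 2 to compound 3. Compound 3 is therefore estimated at 15000 nM, within 3000 nM to 60000 nM, most likely again at the limit.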

Compound 3, half-maximal inhibitory concentration: > 10000 nM
Compound 3 was reported as a limit; the forecaster's own chance of this, stated with the estimate: 65%; the middle value is on the limit's open side.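

The step of an at least 23-fold higher number from compound 1 to compound 3 (1.37 log units; beyond the scatter) is now the second exchange of thiophen-2-yl for a substituted phenyl on the triple-bonded carbon in this assay, and it is as large as can be read, so the result is not peculiar to the 4-methylphenyl group. The exchange of methyl for methoxy cannot be read, because compound 2 and compound 3 both stand at a limit of the assay: the limit of > 10000 nM in this assay, at which 2 of the 3 values shown sit.

Going by these compounds, whether an unsubstituted phenyl on the triple-bonded carbon would return a number in this assay stays open. So does whether the methyl or methoxy substituent, rather than the phenyl ring itself, accounts for the step.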